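The compounds below may be only part of what the source reports. "The series", "measured", "known", "first", "only" and "open" are said of these compounds alone.

Measured compounds and their values:

- Compound 1 `Cc1nn(-c2ncnc3nc[nH]c23)c2c1C(OC1CCCC1)CC(=O)N2`: 2 nM
- Compound 2 `Cc1nn(-c2ncnc3nc[nH]c23)c2c1C(OCc1ccccc1Cl)CC(=O)N2`: 2 nM
- Compound 3 `Cc1nn(-c2ncnc3nc[nH]c23)c2c1C(C(=O)Nc1ccccc1)CC(=O)N2`: 10 nM

These three compounds share one core and differ only in the group attached to a saturated ring carbon. In a functional assay on HEK293 cells for agonist activity at G-protein coupled receptor 39 (Homo sapiens), read by scintillation proximity assay and inositol phosphate accumulation, with a stated time of 75 min, in the presence of a further agent that is not named here (on this read-out higher numbers stand for an effect only at larger amounts of compound and lower numbers for an effect already at smaller amounts), compound 1 gives 2 nM, level with compound 2 and together with it the lowest of the three numbers; the furthest of the three is compound 3, and the change from compound 1 to compound 3 is a 5.0-fold higher number from compound 1 to compound 3 (0.70 log units; beyond the scatter). The step from compound 1 to compound 2, swapping one ether substituent for another, shows no change at the digits printed from compound 1 to compound 2 (within the scatter).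

Compound 4 `Cc1nn(-c2ncnc3nc[nH]c23)c2c1C(C(=O)N(C)c1ccccc1)CC(=O)N2` is not yet measured. Its difference from compound 1 is methyl(phenyl)carbamoyl in place of cyclopentyloxy on a saturated ring carbon. Among the measured compounds shown here, the step that bears most directly on it is the one to compound 3, where phenylcarbamoyl replaced cyclopentyloxy and gave a 5.0-fold higher number from compound 1 to compound 3 (0.70 log units; beyond the scatter); the same exchange from compound 2 gave a 5.0-fold higher number from compound 2 to compound 3 (0.70 log units; beyond the scatter). Compound 4 carries that same amide, with a methyl added on its nitrogen, so a modest rise in number, perhaps somewhat larger than that seen for compound 3, is expected: a 7.5-fold higher number from compound 1 to compound 4 (0.88 log units; beyond the scatter). Compound 4 is therefore estimated at 15 nM, within a range of 4 nM to 60 nM.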

Compound 4, half-maximal effective concentration: 32 nM
Compound 4: middle estimate off by 2.1-fold (0.33 log units), on the low side, within the range that was stated.
By their numbers in this assay, from the lowest: compounds 1 and 2 (each within the scatter of the next); then compound 3; then compound 4.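

In this assay, the amide nitrogen at this saturated ring carbon proves sensitive to a small change: methyl in place of hydrogen gives a 3.2-fold higher number from compound 3 to compound 4 (0.51 log units; beyond the scatter), so the amide series does not tolerate this addition as the two ethers tolerated their exchange. Against the ethers, the whole replacement now amounts to a 16-fold higher number from compound 1 to compound 4 (1.20 log units; beyond the scatter) and a 16-fold higher number from compound 2 to compound 4 (1.20 log units; beyond the scatter), both classed as large, whereas the steps to compound 3 were modest. Cyclopentyloxy and methyl(phenyl)carbamoyl both count no hydrogen-bond donors and one hydrogen-bond acceptor, so those counts do not separate compound 1 from compound 4, and no measurement shown here accounts for the rise.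

The compounds shown leave open whether an ethyl group on the amide nitrogen would move the number further than methyl does, and whether the methyl step would be the same size with cyclopentyl in place of the phenyl ring of the amide. They also leave open how a carboxylic acid or a primary amine would behave on this saturated ring carbon.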